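Cytotoxicity notes: pyridin-3-yl to 3-chlorophenyl

A few compounds are considered here, and "the series" means these few. Any claim that something is new, unique, unknown or untested is made for them only; others in the source may bear on it.

Measured in an ADME assay on MRC5 cells (Homo sapiens) for cytotoxicity, read by fluorescence and resazurin assay, with a stated time of 3 days; on this read-out lower numbers stand for stronger inhibition and higher numbers for weaker inhibition:
- compound 1 `Cc1cn(C2CCN(Cc3cc(Oc4cccc(Cl)c4)ccn3)CC2)c(=O)[nH]c1=O`: > 64000 nM (a limit)
- compound 2 `Cc1cn(C2CCN(Cc3cccc(Oc4cccnc4)c3)CC2)c(=O)[nH]c1=O`: > 64000 nM (a limit)

Compound 2 gives no exact number: it stands at > 64000 nM, which is a limit of the assay. Every result so far has the same form: the limit of > 64000 nM in this assay, at which 2 of the 2 values shown sit. The series therefore offers no measured number from which to judge the size of a structural step.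

Compound 3 `Cc1cn(C2CCN(Cc3cccc(Oc4cccc(Cl)c4)c3)CC2)c(=O)[nH]c1=O` keeps the rest of compound 2 and carries 3-chlorophenyl in place of pyridin-3-yl on an oxygen on an aromatic ring. For the measured compounds named here, no measured pair shows the effect of this change. In this assay, the expected step is none beyond the scatter. This expectation rests on compound 2, whose result of > 64000 nM is a limit. It also rests on compound 1, whose result of > 64000 nM is a limit. A further limit is therefore the likeliest report for compound 3, though a measurable number remains possible.

The expected step is a number no higher from compound 2 to compound 3 (the limit leaves the size open).

For compound 3, the estimated value in this assay is 64000 nM, with an expected range of 28000 nM to 100000 nM.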

Compound 3, half-maximal inhibitory concentration: 21000 nM
Compound 3: the middle estimate sits 3.0-fold (0.48 log units) above what was measured; measured number outside the range, below it.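

In this assay, the swap from pyridin-3-yl to 3-chlorophenyl gives the only exact number among the compounds shown, with an at least 3.0-fold lower number from compound 2 to compound 3 (0.48 log units; beyond the scatter). This shows that the group at this position can move the read-out into the measurable range, but the step is a lower bound and not a size, because compound 2 stands at a limit: the limit of > 64000 nM in this assay, at which 2 of the 3 values shown sit. Compound 1 also carries 3-chlorophenyl and reads > 64000 nM, which is a limit, so among these compounds the group does not bring a measurable number in every setting.

The compounds shown leave open whether the change in compound 3 follows from the added chlorine or from the loss of the ring nitrogen, a question that a plain phenyl on the same oxygen would help to separate. Also open, as far as these compounds go, is how the read-out would respond to other groups on this ring, such as an amine or a carboxylic acid, and how far below the limit the value of compound 2 could lie is not something a limit can tell.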